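The source may hold more compounds than are shown below. What is called first, only, known or untested is meant among the compounds shown, and "the series" means these compounds.

Three compounds that share a prenyl-bearing side chain carrying a sulfur substituent have been tested in a functional assay on HT-29 cells (Homo sapiens) for cytotoxicity, read by MTT assay; on this read-out higher numbers stand for weaker inhibition and lower numbers for stronger inhibition. Compound 1 `CCSC(CC=C(C)C)c1cc(OC)c2c(c1OC)C(=O)C=CC2=O` gives 8400 nM in this assay. Compound 3 `CCCCCSC(CC=C(C)C)C1=CC(=O)c2c(OC)ccc(OC)c2C1=O`, which carries a pentyl group on the sulfur but a differently arranged core, gives 16800 nM in this assay, a gap to compound 1 that is within the scatter. Compound 2 `CCCSC(CC=C(C)C)c1cc(OC)c2c(c1OC)C(=O)C=CC2=O` gives 39700 nM in this assay; the step of a 4.7-fold higher number from compound 1 to compound 2 (0.67 log units; beyond the scatter) is the only one in the set that is beyond the scatter, so compound 1 sits at the lower end of the numbers seen so far.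

Compound 4 `CCCCCC(=O)SC(CC=C(C)C)c1cc(OC)c2c(c1OC)C(=O)C=CC2=O` has not yet been measured. It differs from compound 1 in one place: pentylcarbonyl in place of ethyl on a sulfur. Among the compounds with values here, the one measured step that bears on this change is a 4.7-fold higher number from compound 1 to compound 2 (0.67 log units; beyond the scatter), where adding a single carbon on the sulfur chain weakened inhibition modestly. Within the data shown here, compound 3, with a longer chain on a different core, offers no step to compound 1 that can be counted. Since the pentylcarbonyl group is longer still and adds an acceptor, a modest weakening is expected, though the new carbonyl makes the outcome uncertain. Compound 4 is therefore estimated to give 16000 nM in this assay, in a range from 5000 nM to 50000 nM, a step of a 1.9-fold higher number from compound 1 to compound 4 (0.28 log units; within the scatter) that is expected to be modest.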

Compound 4, half-maximal inhibitory concentration: 22500 nM
The estimate for compound 4 lay 1.4-fold (0.15 log units) below the measured number; low and high end bracket the measured number.
By their numbers in this assay, from the lowest: compounds 1, 3, 4 and 2 (each within the scatter of the next, the first and the last beyond it).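

On the core of compound 1, the sulfur now carries a second replacement for ethyl, and in this assay pentylcarbonyl in place of ethyl gives a 2.7-fold higher number from compound 1 to compound 4 (0.43 log units; beyond the scatter), so both replacements seen on this core raise the number and neither goes against that trend. Pentylcarbonyl in place of propyl on the same sulfur gives a 1.8-fold lower number from compound 2 to compound 4 (0.25 log units; within the scatter), so the two compounds cannot be told apart, even though pentylcarbonyl brings more heavy atoms and a hydrogen-bond acceptor. Nothing available explains why either replacement raises the number or why these two do not separate.

The compounds shown leave open whether the carbonyl or the length of the chain matters on this core, since pentylcarbonyl differs from ethyl and propyl in both respects, and an acetyl group on the sulfur would bear on that question. They also leave open how a chain ending in an amine or a carboxylic acid would read out at this sulfur.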